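The source may hold more compounds than are shown below. What is called first, only, known or untested is meant among the compounds shown, and "the series" means these compounds.

Working notes on the shared core of compound 1 `CC(C)=CCC/C(C)=C/CC/C(C)=C/CC[C@]1(C)CCc2c(C)c(OC(=O)NS(=O)(=O)c3ccc(C)cc3)c(C)c(C)c2O1`, which carries a (4-methylphenyl)sulfonyl group on the amide-type nitrogen. In a functional assay on MDA-MB-231 cells (Homo sapiens) for antiproliferative activity, read by MTT assay, with a stated time of 96 h (a higher number here means a weaker inhibitor, a lower number a stronger inhibitor), compound 1 gives only a limit, > 10000 nM. Compound 2 `CC(C)=CCC/C(C)=C/CC/C(C)=C/CC[C@]1(C)CCc2c(C)c(OC(=O)NC(=O)Oc3ccccc3)c(C)c(C)c2O1` carries a phenoxycarbonyl group in that place. In this assay compound 2 also gives only a limit, > 10000 nM. Compound 3 `CC(C)=CCC/C(C)=C/CC/C(C)=C/CC[C@]1(C)CCc2cc(OC(=O)NC(=O)Oc3ccccc3)c(C)c(C)c2O1` has no result in this assay ("not determined" (no result reported)). Going by the values given here, the single measured step, a step that the two limits leave unreadable from compound 1 to compound 2, cannot be read in size because of the limit of > 10000 nM in this assay, at which 2 of the 3 values shown sit. Compound 2 therefore stands at the limit, with no number to set it against.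

Compound 4 `CC(C)=CCC/C(C)=C/CC/C(C)=C/CC[C@]1(C)CCc2c(C)c(OC(=O)NS(=O)(=O)c3ccccc3)c(C)c(C)c2O1` differs from compound 2 in one place: phenylsulfonyl in place of phenoxycarbonyl on an amide-type nitrogen. The resulting structure lies close to that of compound 1, which sits at the limit as well. With both measured neighbours at the limit, no direction or size of step can be expected beyond the scatter. Compound 4 is accordingly expected to give 15000 nM, with a range of 5000 nM to 40000 nM, most likely reported again as a limit. The expected step that the limit leaves unreadable from compound 2 to compound 4 is thus estimated to stay within the limits.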

Compound 4, half-maximal inhibitory concentration: > 10000 nM
Compound 4 was reported as a limit; the forecaster's own chance of this, stated with the estimate: 80%; the middle value is on the limit's open side.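

Compound 4 also gives only a limit, so its steps to compound 1 and compound 2 cannot be read in size: the limit of > 10000 nM in this assay, at which 3 of the 4 values shown sit.

The compounds shown leave open whether any group on the amide-type nitrogen of the shared core gives a readable number in this assay.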